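The compounds below may be only part of what the source reports. "The series", "measured", "known", "first", "only" and "open" are said of these compounds alone.

Measured compounds in a functional assay for inhibition, using microsomes, tested at 100 ug/mL; on this read-out higher numbers stand for a weaker effect at the one concentration tested and lower numbers for a stronger effect:

- compound 1, `CCOC(=O)C1=C(C)N(c2ccccc2)C=CC1c1ccccc1`: -19.9%
- compound 2, `COC(=O)C1=C(C)N(c2ccccc2)C=CC1c1ccccc1`: -21.5%
- compound 3, `COC(=O)C1=C(C)N(c2ccccc2)C=CC1c1ccc(OC)cc1`: -17.6%

All three share one core and all three readings lie close together. Compound 2 holds the lowest of the three numbers, but neither of its neighbours is set apart from it: the step of a number 1.6 percentage points lower from compound 1 to compound 2 (within the scatter) is within the scatter, and so is the step of a number 3.9 percentage points higher from compound 2 to compound 3 (within the scatter). On the numbers shown, the three compounds cannot be told apart in this assay.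

Compound 4, `CC1=C(C(=O)OC(C)(C)C)C(c2ccccc2)C=CN1c1ccccc1`, is not yet measured. It differs from compound 2 in one place: tert-butyl in place of methyl on an oxygen next to a carbonyl group. The measured step that bears on this place is a number 1.6 percentage points lower from compound 1 to compound 2 (within the scatter), which also alters the group on the oxygen next to the carbonyl group and stays within the scatter. The step of a number 3.9 percentage points higher from compound 2 to compound 3 (within the scatter) touches a different place and is likewise within the scatter. Among the compounds with values here, nothing points to a change beyond the scatter for the move to tert-butyl, so no step of note is expected in this assay in either direction.

Compound 4 is therefore estimated at -20%, with a range of -32% to -8%. The expected step is a number 1.5 percentage points higher from compound 2 to compound 4 (within the scatter).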

Compound 4, a percentage reported as activity, at one concentration (the size of the read-out at that concentration, not a potency): -35.7%
Compound 4: the middle estimate sits 15.7 percentage points above what was measured; measured number below the stated range.
By their numbers in this assay, from the lowest: compound 4; then compounds 2, 1 and 3 (each within the scatter of the next).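

The group on the oxygen next to a carbonyl group is not silent in this assay: the change from methyl to ethyl stayed within the scatter, whereas tert-butyl gives a number 14.2 percentage points lower from compound 2 to compound 4 (beyond the scatter) and a number 15.8 percentage points lower from compound 1 to compound 4 (beyond the scatter). Both steps are beyond the scatter and modest, and both run towards a stronger effect at the one concentration tested, so the result holds against either of the two smaller groups, and the earlier flat readings at this position do not extend to tert-butyl. No measured evidence bears on what lies behind this step.

It remains open whether an isopropyl group or a longer chain on that oxygen would read with compound 4 or with compounds 1 and 2, so the compounds shown cannot tell whether the step belongs to tert-butyl alone or to a wider set of groups. Also open, on these data alone, are whether tert-butyl gives a similar step on the methoxy-bearing compound 3, and whether a carboxylic acid at this place would retain any of the effect.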